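A non-aromatic ring replaces the thiadiazole on the amide

The compounds below may be only part of what the source reports. "The series", "measured", "known", "first", "only" and "open" are said of these compounds alone.

The two measured compounds share one core and differ only in the group on the amide-type nitrogen. Compound 1 `CC(C)[C@H](C(=O)Nc1ccccc1)c1ccc(Cl)cc1` gives only a limit in a functional assay on CHO cells for agonist activity at Free fatty acid receptor 2 (Homo sapiens), read by cAMP accumulation (on this read-out higher numbers stand for weaker inhibition and lower numbers for stronger inhibition), > 100000 nM. Compound 2 `CC(C)[C@H](C(=O)Nc1cnns1)c1ccc(Cl)cc1` gives 57000 nM in this assay, the only number shown. Going by the values given here, the step of an at least 1.7-fold lower number from compound 1 to compound 2 (0.24 log units; that floor lies within the scatter) is the only measured step, and because the limit of > 100000 nM in this assay, at which 1 of the 2 values shown sits, its size has only a floor.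

Compound 3 `CC(C)[C@H](C(=O)NC1=NC(=O)CS1)c1ccc(Cl)cc1` has not been measured. It carries a group of 6 heavy atoms (3 carbon, 1 nitrogen, 1 oxygen, 1 sulfur; one five-membered non-aromatic ring with 2 hetero atoms) in place of a group of 5 heavy atoms (2 carbon, 2 nitrogen, 1 sulfur; one five-membered aromatic ring with 3 hetero atoms), on an amide-type nitrogen. Among the compounds with values here, the one measured step, an at least 1.7-fold lower number from compound 1 to compound 2 (0.24 log units; that floor lies within the scatter), does not reach beyond the scatter at its floor, so no step beyond the scatter is expected for compound 3 in this assay in either direction. Compound 3 is therefore expected to give 55000 nM, within 15000 nM to 200000 nM. That estimate means an expected step of a 1.0-fold lower number from compound 2 to compound 3 (0.02 log units; within the scatter).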

Compound 3, half-maximal inhibitory concentration: 20000 nM
The estimate for compound 3 lay 2.8-fold (0.44 log units) above the measured number; the measured number falls inside the stated range.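

Going by these compounds alone, compound 3 gives the first step on this amide-type nitrogen that is beyond the scatter in this assay: a 2.9-fold lower number from compound 2 to compound 3 (0.45 log units; beyond the scatter). Among these compounds, then, an aromatic ring on this nitrogen is not needed for a lower number, and the comparison with the phenyl group, an at least 5.0-fold lower number from compound 1 to compound 3 (0.69 log units; beyond the scatter), now clears the scatter even at its floor. Compound 1 stands at a limit and not at a number, so that step has only a floor: the limit of > 100000 nM in this assay, at which 1 of the 3 values shown sits.

Going by these compounds, the ring atoms, the loss of aromatic character and the double bonds outside the ring all change together in the step to compound 3, and which of them goes with the lower number stays open. Also open, on these data alone, is how this ring would read with a carboxylic acid or an amine attached to it.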